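A few compounds are considered here, and "the series" means these few. Any claim that something is new, unique, unknown or untested is made for them only; others in the source may bear on it.

Within the data shown here, compound 1 `FC(F)(F)c1nc2c(-c3ccccc3)cccc2c(-c2ccccc2)c1-c1ccccc1` is one of two compounds measured in an assay for inhibition of ectonucleoside triphosphate diphosphohydrolase 1 (Homo sapiens), read by malachite green, with a stated time of 10 min; a higher number here means a weaker inhibitor, a lower number a stronger inhibitor. In this assay compound 1 gives only a limit, > 300000 nM, and no number. Compound 2 `COc1ccc(OC)c(-c2cccc3c(Cl)c(Br)c(C(F)(F)F)nc23)c1` is the other. In this assay compound 2 likewise gives only a limit, > 300000 nM. Both sit at the limit of > 300000 nM in this assay, at which 2 of the 2 values shown sit, so compound 1 cannot be ranked against compound 2. Compound 3 `FC(F)(F)c1nc2c(-c3ccccc3)cccc2c(Cl)c1-c1ccccc1` is not yet measured. It differs from compound 1 by chloro in place of phenyl on an aromatic carbon. Nothing measured here shows a step of known size, so the expected step of a number no higher from compound 1 to compound 3 (the limit leaves the size open) is none beyond the scatter. Compound 3 is expected to give about 300000 nM, within 100000 nM to 1000000 nM, most likely again only as a limit.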

Compound 3, half-maximal inhibitory concentration: > 300000 nM
Compound 3 gave a limit, no number (the forecaster's own chance of this, stated with the estimate: 85%); the middle value lies on the limit itself.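

No step can be read between compound 1 and compound 3, since each gives only a limit in this assay: the limit of > 300000 nM in this assay, at which 3 of the 3 values shown sit.

How strongly any of these compounds inhibits, and what swapping phenyl for chloro does to that, stays open.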